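The source may hold more compounds than are shown below. What is called first, only, known or untested is meant among the compounds shown, and "the series" means these compounds.

Measured so far:
Compound 1 `CCSc1nc(N)c2nc(O)n(Cc3ccccc3)c2n1`: 0.1 mg/kg
Compound 2 `CCCCc1nc(N)c2nc(O)n(Cc3ccccc3)c2n1`: 0.3 mg/kg

Both numbers come from a functional assay on the whole organism for activation, with Mus musculus as the target; a lower number here means that less compound is needed, a higher number that more compound is needed for the effect. Compound 2 stands highest of the two; its nearest neighbour is compound 1, reached by a 3.0-fold higher number from compound 1 to compound 2 (0.48 log units; beyond the scatter) read in reverse. Compound 3 `CCCOc1nc(N)c2nc(O)n(Cc3ccccc3)c2n1` differs from compound 2 by propoxy in place of butyl on an aromatic carbon. Within the data shown here, the one measured step, a 3.0-fold higher number from compound 1 to compound 2 (0.48 log units; beyond the scatter), bears on this only loosely: it shows a modest rise when butyl replaces a chain that is joined to the ring through a non-carbon atom, and going back to such a chain would, if anything, be expected to lower the number for compound 3. Compound 3 is therefore estimated at 0.15 mg/kg, with a range from 0.05 mg/kg to 0.5 mg/kg. The expected step, a 2.0-fold lower number from compound 2 to compound 3 (0.30 log units; within the scatter), is near the edge of the scatter.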

Compound 3, minimum effective dose: 0.3 mg/kg
Beside the measured number, compound 3's estimate is 2.0-fold (0.30 log units) below it, and the stated range covers the measured number.
By their numbers in this assay, from the lowest: compound 1; then compounds 2 and 3 (each within the scatter of the next).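

Propoxy and butyl have the same number of heavy atoms, yet propoxy brings in an oxygen and a hydrogen-bond acceptor, and this exchange gives no change at the digits printed from compound 2 to compound 3 (within the scatter) in this assay. Propoxy in place of ethylsulfanyl gives a 3.0-fold higher number from compound 1 to compound 3 (0.48 log units; beyond the scatter), so among these three compounds only the ethylsulfanyl chain stands apart, whether the replacement chain is joined through carbon or oxygen. No measurement shown here explains this.

Going by these compounds, it remains open whether the sulfur atom or the shorter chain sets compound 1 apart, a question that ethoxy or propylsulfanyl at this position could address. On these data alone, how an amine there would behave also remains open.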